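This account rests on a few compounds, and the source may have more. Where it says the series, first, only, none or still open, it means among the compounds named here.

Working notes on the series. Compound 1 `CC(=O)/C=C/c1cccc(C(C)(C)C)c1O` gives 2190 nM in a functional assay for inhibition, with Oryctolagus cuniculus as the target; on this read-out lower numbers stand for stronger inhibition and higher numbers for weaker inhibition. For the measured compounds named here, compound 2 `CCOc1cccc(/C=C/C(C)=O)c1O` gives 3310 nM in this assay, the highest of the two numbers so far; the one measured step, a 1.5-fold higher number from compound 1 to compound 2 (0.18 log units; within the scatter), leaves compound 1 and compound 2 within the scatter of each other, so no order between them is claimed.

The next step goes from compound 2 to compound 3 `CC(=O)/C=C/c1cccc(O)c1O`. The change is hydrogen in place of ethyl on an oxygen on an aromatic ring; the ethyl group leaves and only the hydroxy remains on the core of compound 2. Going by the values given here, no measured step touches this oxygen: the only step recorded, tert-butyl to ethoxy on an aromatic carbon in a 1.5-fold higher number from compound 1 to compound 2 (0.18 log units; within the scatter), concerns a different position and was within the scatter. Among the compounds with values here, there is therefore no precedent for the size or direction of the new step, and the default expectation is a change not clearly beyond the scatter.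

Compound 3 is expected to land near compound 2 in this assay, with the step of a 1.1-fold lower number from compound 2 to compound 3 (0.04 log units; within the scatter). The estimate for compound 3 is 3000 nM, within a range of 1000 nM to 10000 nM.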

Compound 3, half-maximal inhibitory concentration: 1960 nM
The estimate for compound 3 lay 1.5-fold (0.18 log units) above the measured number, within the range that was stated.
By their numbers in this assay, from the lowest: compounds 3, 1 and 2 (each within the scatter of the next).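

Replacing ethyl with hydrogen on this oxygen, the change from ethoxy to hydroxy, gives a 1.7-fold lower number from compound 2 to compound 3 (0.23 log units; within the scatter) in this assay, so the ethyl group can leave without a difference that stands clear of the scatter. Read together with a 1.1-fold lower number from compound 1 to compound 3 (0.05 log units; within the scatter), this extends the earlier picture from two groups to three: tert-butyl, ethoxy and hydroxy on the same aromatic carbon of the shared core all give numbers within the scatter of one another, and no order among compound 1, compound 2 and compound 3 can be claimed. No supporting measurement bears on this result.

The compounds shown leave open whether a longer chain or a benzyl group on this oxygen, or an amine or a carboxylic acid on the same aromatic carbon, would give a number beyond the scatter. For the compounds shown here, also open is what a change elsewhere on the shared core would do, for instance an amide in place of the ketone, as every step so far lies within the scatter.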